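Swapping the Amide Aryl Group of Compound 1

The source may hold more compounds than are shown below. What is called first, only, known or untested is meant among the compounds shown, and "the series" means these compounds.

Three compounds share a core in which an amide links an aromatic acid to a bicyclic amine. In a functional assay on MCF7 cells (Homo sapiens) for antiproliferative activity, read by MTT assay, with a stated time of 72 h (on this read-out higher numbers stand for weaker inhibition and lower numbers for stronger inhibition), compound 1 `CCN1CCN(c2cc(C)c3cc(NC(=O)c4ccc(OC)cc4)ccc3n2)CC1` gives 7690 nM, which is the second highest of the three numbers. Compound 2 `Cc1cc(N2CCCCC2)nc2ccc(NC(=O)c3ccc(Cl)c(Cl)c3)cc12` gives 31100 nM and compound 3 `Cc1cc(NCCN2CCCC2)nc2ccc(NC(=O)c3ccc(Cl)c(Cl)c3)cc12` gives 1280 nM. Among the compounds with values here, the only step measured within this set is a 24-fold lower number from compound 2 to compound 3 (1.39 log units; beyond the scatter), and it concerns the group on the aromatic carbon of the core, not the amide side.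

Compound 4 `CCN1CCN(c2cc(C)c3cc(NC(=O)c4cccc(C)c4)ccc3n2)CC1` differs from compound 1 on the amide side: 3-methylphenyl in place of 4-methoxyphenyl on a carbonyl carbon. Within the data shown here, no measured step touches that part of the molecule, so the data give no direct guide to the size or direction of the change in this assay. With nothing to point one way, a change within the scatter is expected, which in this assay means a step of roughly a 1.2-fold higher number from compound 1 to compound 4 (0.07 log units; within the scatter). Compound 4 is therefore estimated at 9000 nM, with a likely range from 3000 nM to 27000 nM.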

Compound 4, half-maximal inhibitory concentration: 7800 nM
For compound 4 the middle estimate is 1.2-fold (0.06 log units) above the measured one; the range from low to high includes it.
By their numbers in this assay, from the lowest: compound 3; then compounds 1 and 4 (each within the scatter of the next); then compound 2.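

Within the data shown here, this is the first measured step on the amide side of the molecule: in this assay the swap gives a 1.0-fold higher number from compound 1 to compound 4 (0.01 log units; within the scatter) and so no readable change. The group that leaves has a hydrogen-bond acceptor and the group that enters has none, yet the two compounds stay within the scatter of each other, so for this pair that difference does not appear in the read-out. Nothing measured here explains this outcome.

Going by these compounds, a single pair says little about the amide side as a whole, and it remains open whether a phenyl ring carrying an amine or a carboxylic acid would also leave the number in place. Also open, on these data alone, is whether (2-(pyrrolidin-1-yl)ethyl)amino, the group on the core of compound 3, would lower the number of compound 4.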